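The source may report more compounds than this note shows. Statements on the series, on what has been measured and on what is new or still open speak of the compounds shown alone.

Compound 1 `COc1ncnc2c1c(-c1ccoc1)cn2[C@@H]1O[C@H](CO)[C@@H](O)[C@H]1O` and compound 2 `CN(C)c1ncnc2c1c(-c1ccoc1)cn2[C@@H]1O[C@H](CO)[C@@H](O)[C@H]1O` share a furan-3-yl group on the shared core and differ only at one aromatic carbon. In a functional assay on CCRF-CEM cells (Homo sapiens), read by MTT assay, with a stated time of 72 h (a higher number here means a weaker inhibitor, a lower number a stronger inhibitor), compound 1 gives 110 nM. In this assay, going by the values given here, compound 2 gives 13300 nM, and the step of a 120-fold higher number from compound 1 to compound 2 (2.08 log units; beyond the scatter) is the only measured change in this set. Compound 3 `CNc1ncnc2c1c(-c1ccccc1)cn2[C@@H]1O[C@H](CO)[C@@H](O)[C@H]1O` carries a methylamino group and a phenyl group. In this assay compound 3 gives only a limit of the assay, > 20000 nM, which is the limit noted as the limit of > 20000 nM in this assay, at which 1 of the 3 values shown sits.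

Compound 4 `CNc1ncnc2c1c(-c1ccoc1)cn2[C@@H]1O[C@H](CO)[C@@H](O)[C@H]1O` keeps the methylamino group of compound 3 and differs from it by furan-3-yl in place of phenyl on an aromatic carbon. No measured step bears on this exchange of phenyl for furan-3-yl; the single measured step concerns the group at a different aromatic carbon, and compound 3 itself sits at a limit, so the size of the step from compound 3 to compound 4 cannot be read from the numbers shown. The values of compound 1 and compound 2, both with furan-3-yl, only bracket what this ring has so far accompanied. Compound 4 is therefore expected to give 2000 nM in this assay, within a range from 300 nM to 15000 nM. That estimate would mean a step of an at least 10-fold lower number from compound 3 to compound 4 (1.00 log units; beyond the scatter) from the limit of compound 3 to compound 4.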

Compound 4, half-maximal inhibitory concentration: > 20000 nM
Compound 4 ended at the assay's limit; the forecaster's own chance of this, stated with the estimate: 15%; middle value at least 10-fold (1.00 log units) from the limit.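

With furan-3-yl held in place, swapping the methoxy group for a methylamino group gives an at least 180-fold higher number from compound 1 to compound 4 (2.25 log units; beyond the scatter) in this assay, so a second nitrogen group at this carbon, after the dimethylamino group of compound 2, also stands far from methoxy. Among compound 1, compound 2 and compound 4, methoxy is thus the only group at this carbon that goes with a value far from the limit of the assay, and none of these three goes against that pattern. Hydrogen in place of methyl on the nitrogen gives an at least 1.5-fold higher number from compound 2 to compound 4 (0.17 log units; that floor lies within the scatter) and, with that floor lying within the scatter, the two nitrogen groups cannot be put in order, while the exchange of phenyl for furan-3-yl cannot be read, as compound 3 and compound 4 both rest at a limit of the assay: the limit of > 20000 nM in this assay, at which 2 of the 4 values shown sit.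

The compounds shown leave open whether the low value belongs to methoxy alone or would also go with an ethoxy group, a methylthio group or an unsubstituted amine at this carbon. They also leave open what the ring carrying furan-3-yl contributes, which a thiophene-3-yl group alongside methoxy could begin to answer.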